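Hydroxy to methoxy step carried onto the naphthamide series

The compounds below may be only part of what the source reports. "The series", "measured", "known", "first", "only" and "open" are said of these compounds alone.

Three compounds share a core and differ in the aryl amide. Compound 1 `CC(C)(CNC(=O)c1ccccc1O)CC1=C(O)C(=O)c2ccccc2C1=O` carries a hydroxy on its aryl ring; compound 2 `COc1ccccc1C(=O)NCC(C)(C)CC1=C(O)C(=O)c2ccccc2C1=O` is its methoxy counterpart; compound 3 `COc1cc(C(=O)NCC(C)(C)CC2=C(O)C(=O)c3ccccc3C2=O)c(O)c2ccccc12` carries a larger aromatic amide with both a hydroxy and a methoxy. In a functional assay on KB cells (Homo sapiens) for cytotoxicity, read by resazurin assay, with a stated time of 3 days (a higher number here means a weaker inhibitor, a lower number a stronger inhibitor), compound 1 gives 44900 nM, compound 2 gives 26300 nM, and compound 3 gives 8620 nM. The move from compound 1 to compound 2 is methyl in place of hydrogen on an oxygen on an aromatic ring; it gave a 1.7-fold lower number from compound 1 to compound 2 (0.23 log units; within the scatter), so the two values cannot be ordered. Compound 3 holds the lowest number of the three, with its steps to compound 2 and compound 1 both beyond the scatter; the difference between the core of compound 3 and that of compound 1 is not broken down here.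

Compound 4 `COc1cc(C(=O)NCC(C)(C)CC2=C(O)C(=O)c3ccccc3C2=O)c(OC)c2ccccc12` is not yet measured in this assay. It differs from compound 3 by methyl in place of hydrogen on an oxygen on an aromatic ring, which is the same change as that from compound 1 to compound 2, at a place described in identical words. Among the compounds with values here, the expectation for compound 4 rests on the one earlier example: the step from compound 3 to compound 4 is estimated as a 1.7-fold lower number from compound 3 to compound 4 (0.24 log units; within the scatter), taken to match the small movement seen from compound 1 to compound 2 in this assay rather than a larger one, because of a 1.7-fold lower number from compound 1 to compound 2 (0.23 log units; within the scatter). Compound 4 is therefore expected to give 5000 nM in this assay, with a range estimated from 2500 nM to 12000 nM; a single prior example gives no firm footing.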

Compound 4, half-maximal inhibitory concentration: 47000 nM
Beside the measured number, compound 4's estimate is 9.4-fold (0.97 log units) below it, outside the stated range (above it).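

In this assay, hydroxy to methoxy on the larger aromatic amide gave a 5.5-fold higher number from compound 3 to compound 4 (0.74 log units; beyond the scatter), a step that can be read, while the same change on the smaller aryl amide gave a 1.7-fold lower number from compound 1 to compound 2 (0.23 log units; within the scatter), a step that cannot be ordered; the two steps do not agree: the same change on two cores in this assay, a 1.7-fold lower number (0.23 log units; within the scatter) from compound 1 to compound 2 and a 5.5-fold higher number (0.74 log units; beyond the scatter) from compound 3 to compound 4, 9.3-fold (0.97 log units) apart, beyond the scatter of two such steps. Within the data shown here, the change therefore does not carry from one core to the other as a fixed step, and the small movement on the first pair is no guide to the second. These two pairs do not show why the steps differ, do not set a rule for any other core in the series, and do not give the first pair a direction that could be called opposite to the second.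

From the compounds shown here alone, it remains open whether the free hydroxy itself matters on the core of compound 3 or whether any group on that oxygen gives a similar rise, as an ethyl or a longer chain there would test. Replacing the hydroxy with an amine would also test whether another group can stand in its place and keep the number near that of compound 3.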